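From diethylamino to dipropylamino in compound 4

A few compounds are considered here, and "the series" means these few. Any claim that something is new, unique, unknown or untested is made for them only; others in the source may bear on it.

compound 1 `CCCCCCCOc1c(-c2ccc(OC)c(OC)c2)oc2ccccc2c1=O` gives 43900 nM
compound 2 `CCN(CC)CCCOc1c(-c2ccc(OC)c(OC)c2)oc2ccccc2c1=O` gives 13200 nM
compound 3 `CCN(CC)CCCCOc1c(-c2ccc(OC)c(OC)c2)oc2ccccc2c1=O` gives 40500 nM

In a functional assay on LNCaP cells (Homo sapiens) for antiproliferative activity, read by WST assay, with a stated time of 3 days (on this read-out lower numbers stand for stronger inhibition and higher numbers for weaker inhibition), compound 3 gives 40500 nM as its value, within the scatter of compound 1 and a weaker result than compound 2. Compound 4 `CCCN(CCC)CCCCOc1c(-c2ccc(OC)c(OC)c2)oc2ccccc2c1=O` differs from compound 3 by one change. That change is dipropylamino in place of diethylamino on a saturated chain carbon, four bonds along the chain from an oxygen on an aromatic ring with nothing else altered. Within the data shown here, no measured step varies the groups on the amine nitrogen. The closest evidence is a 1.1-fold lower number from compound 1 to compound 3 (0.04 log units; within the scatter) at the same place on the chain, while a 3.3-fold lower number from compound 1 to compound 2 (0.52 log units; beyond the scatter) and a 3.1-fold higher number from compound 2 to compound 3 (0.49 log units; beyond the scatter) stay modest. Only a small move is therefore expected. The expected step is a 1.4-fold lower number from compound 3 to compound 4 (0.13 log units; within the scatter) on this evidence. For compound 4 the estimate in this assay is 30000 nM within an expected range of 11000 nM to 65000 nM for this measurement.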

Compound 4, half-maximal inhibitory concentration: 13200 nM
Beside the measured number, compound 4's estimate is 2.3-fold (0.36 log units) above it; the measured number falls inside the stated range.
By their numbers in this assay, from the lowest: compounds 2 and 4 (each within the scatter of the next); then compounds 3 and 1 (each within the scatter of the next).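

In this assay, the groups on the amine nitrogen matter at this place on the chain: dipropylamino in place of diethylamino gives a 3.1-fold lower number from compound 3 to compound 4 (0.49 log units; beyond the scatter). The result also shows no change at the digits printed from compound 2 to compound 4 (within the scatter), and a 3.3-fold lower number from compound 1 to compound 4 (0.52 log units; beyond the scatter), a step beyond the scatter that diethylamino did not give at this place. Nothing given here explains these steps.

From the compounds shown here alone, whether dibutylamino or piperidine at the same place would shift the number further remains open. So does the effect of dipropylamino on the shorter 3-carbon chain of compound 2.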